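Inverting one ring stereocentre in a bicyclic thiadiazole

The source may hold more compounds than are shown below. What is called first, only, known or untested is meant among the compounds shown, and "the series" means these compounds.

Of the compounds shown here, two have been measured so far in a functional assay on the whole organism for inhibition, with Mus musculus as the target; on this read-out lower numbers stand for an effect already at smaller amounts and higher numbers for an effect only at larger amounts of compound. Compound 1 `CCCCSc1nsnc1[C@H]1CN2CCC[C@@H]1C2` gives 0.012 mg/kg in this assay, and compound 2 `CCCSc1nsnc1[C@H]1CN2CCC[C@@H]1C2` gives 0.021 mg/kg. For the measured compounds named here, the only step between them, a 1.8-fold higher number from compound 1 to compound 2 (0.24 log units; within the scatter), so compound 2 and compound 1 stand within the scatter of each other, and compound 2 is the only other point in the set.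

Compound 3 `CCCSc1nsnc1[C@@H]1CN2CCC[C@@H]1C2` is the next compound. Its difference from compound 2 is the two compounds have the same atoms and bonds; at least one stereo element is drawn with a configuration in one of them and without one in the other: 1 of 3 stereo elements differ; a stereocentre at a saturated ring carbon is drawn R in compound 2 and S in compound 3. Going by the values given here, no measured step touches a stereocentre; the single known step concerns only chain length, so nothing in the data shows how this assay responds to such a change. The estimate for compound 3 therefore rests on compound 2 alone, with a wide range: compound 3 is expected to give 0.1 mg/kg (0.015 mg/kg to 1.5 mg/kg), which would be a step of a 4.8-fold higher number from compound 2 to compound 3 (0.68 log units; beyond the scatter).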

Compound 3, dose for half-maximal effect: 2.2 mg/kg
For compound 3 the middle estimate is 22-fold (1.34 log units) below the measured one; the measured number lies above the stated range.
By their numbers in this assay, from the lowest: compounds 1 and 2 (each within the scatter of the next); then compound 3.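

In this assay, for the compounds shown here, the configuration at a saturated ring carbon turns out to matter far more than anything the earlier compounds revealed: with atoms and bonds unchanged, going from R to S gives a 100-fold higher number from compound 2 to compound 3 (2.02 log units; beyond the scatter). Going by these compounds alone, the only earlier step, the shortening of the chain between compound 1 and compound 2, stayed within the scatter, so this stereocentre is the first place in the set where the read-out clearly responds. One point about the drawings limits how cleanly the step can be assigned to the inversion alone: the fact that one of compounds 2 and 3 is drawn with a defined configuration and the other without, at the place where they differ

Going by these compounds, whether the same inversion has an equally large effect with the butyl chain of compound 1 remains open. Also open, on these data alone, is how a pentyl chain or a benzyl group on the sulfur would fare at either configuration.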